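Dropping the chloro from compound 2: a single-atom change

A few compounds are considered here, and "the series" means these few. Any claim that something is new, unique, unknown or untested is made for them only; others in the source may bear on it.

Measured compounds:
- Compound 1, `O=C(O)c1n[nH]c2ccc(NCc3ccccc3)cc12`: 22000 nM
- Compound 2, `CN(C)c1noc(-c2cccc(CNc3ccc4[nH]nc(C(=O)O)c4c3)c2Cl)n1`: 180 nM
- Compound 3, `CN(C)c1noc(-c2cccc(CNc3cnc4nn[nH]c4c3)c2O)n1`: 2900 nM

In an assay on isolated protein for inhibition of 2-Hydroxyacid oxidase 1 (Homo sapiens), with stated times of 30 min and 15 min (on this read-out higher numbers stand for weaker inhibition and lower numbers for stronger inhibition), compound 1 gives 22000 nM, and compound 3 gives 2900 nM. Compound 2 has the lowest number of the three, with compound 3 the nearest to it and compound 1 the furthest, both gaps beyond the scatter, so compound 2 is the strongest inhibitor among the measured set. Compound 3 differs from compound 2 in more than one place, so its gap to compound 2 cannot be laid on any single change.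

Compound 4, `CN(C)c1noc(-c2cccc(CNc3ccc4[nH]nc(C(=O)O)c4c3)c2)n1`, has not yet been measured in this assay. It differs from compound 2 only by hydrogen in place of chloro on an aromatic carbon. Among the measured compounds shown here, no measured pair in this set shows the same change, so the expectation rests on the standing of compound 2 alone. Since compound 2 sits at the strong end of the measured range, a modest loss on removing the chloro is expected rather than a gain, though a step within the scatter is also plausible. The expected step from compound 2 to compound 4 is a 2.8-fold higher number from compound 2 to compound 4 (0.44 log units; beyond the scatter). Compound 4 is estimated at 500 nM, with a range from 150 nM to 2000 nM.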

Compound 4, half-maximal inhibitory concentration in the 2-Hydroxyacid oxidase 1 assay: 170 nM
Estimate against measurement, compound 4: 2.9-fold (0.47 log units) above; measured number inside the range.
By their numbers in the 2-Hydroxyacid oxidase 1 assay, from the lowest: compounds 4 and 2 (each within the scatter of the next); then compound 3; then compound 1.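

In the 2-Hydroxyacid oxidase 1 assay, the chloro on this aromatic carbon, ortho to a 3-(dimethylamino)-1,2,4-oxadiazol-5-yl group, proves not to be needed for inhibition: with a 1.1-fold lower number from compound 2 to compound 4 (0.02 log units; within the scatter), compound 2 and compound 4 cannot be told apart. Among the compounds shown here, removing it also gives the first single-place comparison with compound 1, and in the 2-Hydroxyacid oxidase 1 assay the large step, a 130-fold lower number from compound 1 to compound 4 (2.11 log units; beyond the scatter), shows how much inhibition goes with adding the 3-(dimethylamino)-1,2,4-oxadiazol-5-yl group alone, something compound 2 could not show while it differed from compound 1 in two places. In a physicochemical assay for solubility, measured as kinetic solubility, at pH 2 (on this read-out lower numbers stand for lower solubility and higher numbers for higher solubility), compound 2 gives 7000 nM and compound 4 gives 308000 nM, so the change that is silent for inhibition is far from silent for solubility: the measured solubility of compound 2, 7000 nM, and of compound 4, 308000 nM, a 44-fold higher number (1.64 log units; beyond the scatter)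

On these data alone, only chloro and hydrogen can be compared directly at this carbon, so it remains open whether a methyl, a methoxy or an amine there would also leave inhibition in place, and where solubility would then fall. The gap between compound 3 and compound 4 still spans more than one place, so the compounds shown do not tell what the carboxylic acid on the core contributes.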